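Trading bromo for trifluoromethyl on compound 2

The compounds below may be only part of what the source reports. "The series", "measured", "known", "first", "only" and "open" are said of these compounds alone.

Compound 1 `CN1C/C(=C\c2ccc(C(F)(F)F)cc2)C(=O)/C(=C/c2ccccc2F)C1`: 6340 nM
Compound 2 `CN1C/C(=C\c2ccc(Br)cc2)C(=O)/C(=C/c2ccc(C#N)cc2)C1`: 7420 nM

In a functional assay on K562 cells (Homo sapiens) for cytotoxicity, read by MTT assay, with a stated time of 24 h (on this read-out higher numbers stand for weaker inhibition and lower numbers for stronger inhibition), compound 2 gives 7420 nM and compound 1 gives 6340 nM. These two values lie within the usual scatter of each other, so the numbers do not separate the compounds. Compound 3 `CN1C/C(=C\c2ccc(C#N)cc2)C(=O)/C(=C/c2ccc(C(F)(F)F)cc2)C1` has not yet been measured. It differs from compound 2 in one place, with trifluoromethyl in place of bromo on an aromatic carbon. Among the measured compounds shown here, no measured pair differs in just one place, so the data offer no direct guide to the size of this step. Compound 1 also carries a trifluoromethyl group and gives 6340 nM, so no step beyond the scatter is expected in this assay, in either direction. The estimated change is a 1.1-fold lower number from compound 2 to compound 3 (0.06 log units; within the scatter). For compound 3 the estimated value is 6500 nM, with an expected range from 3000 nM to 14000 nM.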

Compound 3, half-maximal inhibitory concentration: 4010 nM
For compound 3 the middle estimate is 1.6-fold (0.21 log units) above the measured one, and the stated range covers the measured number.
By their numbers in this assay, from the lowest: compounds 3, 1 and 2 (each within the scatter of the next).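

Among the compounds shown here, the first direct reading of this change shows that, in this assay, trifluoromethyl in place of bromo on an aromatic carbon gives a 1.9-fold lower number from compound 2 to compound 3 (0.27 log units; within the scatter), so bromo and trifluoromethyl are not told apart at this position, at least with the rest of compound 3 as it stands. A second single change, 4-cyanophenyl in place of 2-fluorophenyl, gives a 1.6-fold lower number from compound 1 to compound 3 (0.20 log units; within the scatter), so this change does not separate its two compounds either. No measurement at hand gives a reason for either result.

Still open, going by these compounds, is whether any group at this aromatic carbon can give a step beyond the scatter, for example an amine or a carboxylic acid in place of trifluoromethyl. Also open, on these data alone, is whether bromo and trifluoromethyl would stay as close on a different partner ring, such as the 2-fluorophenyl of compound 1.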